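Swapping the aryl group on the sulfonyl sulfur

The source may report more compounds than this note shows. Statements on the series, on what has been measured and on what is new or still open speak of the compounds shown alone.

Compound 1 `COc1ccc(-c2cc(=O)c3c(OC)cc(OC)cc3[nH]2)cc1` gives > 62000 nM in an ADME assay on BJ cells (Homo sapiens) for antiproliferative activity, with a stated time of 72 h (a higher number here means that more compound is needed for the effect, a lower number that less compound is needed), a limit of the assay.
Compound 2 `COc1ccc(-c2cc(=O)c3c(OC)cc(OC)cc3n2S(=O)(=O)c2ccc(F)cc2)cc1` gives > 65500 nM in this assay, again a limit.

Compound 2 therefore stands only at a limit, with nothing to separate it from compound 1: both values sit at limits, the limit of > 62000 nM in this assay, at which 1 of the 2 values shown sits, and (the limit of > 65500 nM in this assay, at which 1 of the 2 values shown sits), so the step that the two limits leave unreadable from compound 1 to compound 2 stays unreadable. Compound 3 `COc1ccc(-c2cc(=O)c3c(OC)cc(OC)cc3n2S(=O)(=O)c2cccc(Br)c2)cc1` differs from compound 2 by 3-bromophenyl in place of 4-fluorophenyl on a sulfonyl sulfur. Among the compounds with values here, no measured step touches this part of the molecule, and the one measured step is unreadable, so no change beyond the scatter is expected in this assay. Compound 3 is estimated at 70000 nM (range 30000 nM to 200000 nM), most likely again a limit, meaning an expected step that the limit leaves unreadable from compound 2 to compound 3.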

Compound 3, half-maximal effective concentration: > 58600 nM
Compound 3: no number, only a limit; the forecaster's own chance of this, stated with the estimate: 85%; the middle value lies beyond the limit too.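

Compound 3 also stands only at a limit of the assay, so its steps from compound 1 and compound 2 cannot be read. Going by these compounds, whether the aryl group on the sulfonyl sulfur affects the concentration needed in this assay remains open.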